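The source may report more compounds than this note shows. Statements on the series, on what has been measured and on what is new or still open speak of the compounds shown alone.

In a functional assay on SW1573 cells (Homo sapiens) for antiproliferative activity, read by sulforhodamine B assay, with a stated time of 48 h (a lower number here means a stronger inhibitor of growth, a higher number a weaker inhibitor of growth), the measured compounds are:
compound 1, `COC(=O)C#CC(O/C=C/C(=O)OC)C(C)c1ccccc1`, with 1200 nM
compound 2, `CC1CCC(C(C)C)C(OC(=O)C#CC(O/C=C/C(=O)OC2CC(C)CCC2C(C)C)C(C)C)C1`, reported only as a limit, > 100000 nM
compound 3, `CCCCCC(C#CC(=O)OC)O/C=C/C(=O)OC`, with 1700 nM

Compound 3 holds the higher of the two numbers that were actually read, but its nearest neighbour, compound 1, sits within the usual scatter of it, so the two cannot be told apart on these data. Compound 2 stands apart only as a limit (the limit of > 100000 nM in this assay, at which 1 of the 3 values shown sits), and nothing more can be said of it.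

For the measured compounds named here, no two measured compounds differ in just one place, so no single step has been measured here. Compound 4, `CCCCC(C#CC(=O)OC)O/C=C/C(=O)OC`, is the new compound. It differs from compound 3 in one way: hydrogen in place of methyl on a saturated chain carbon, five bonds along the chain from an oxygen on an unsaturated carbon and a triple-bonded carbon. The change trims the chain at its far end and leaves the rest of compound 3 untouched.

Going by the values given here, with no measured step of this kind to lean on, the expectation is that compound 4 lands close to compound 3, with the step of a 1.2-fold higher number from compound 3 to compound 4 (0.07 log units; within the scatter) expected to stay within the scatter. Compound 4 is therefore estimated at 2000 nM in this assay, with a range from 900 nM to 4500 nM.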

Compound 4, concentration for 50% growth inhibition: 240 nM
Estimate against measurement, compound 4: 8.3-fold (0.92 log units) above; the whole stated range lies above it.
By their numbers in this assay, from the lowest: compound 4; then compounds 1 and 3 (each within the scatter of the next). At a limit, above all of these: compound 2.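

In this assay the far end of the chain proves to matter: hydrogen in place of methyl on a saturated chain carbon, five bonds along the chain from an oxygen on an unsaturated carbon and a triple-bonded carbon, gives a 7.1-fold lower number from compound 3 to compound 4 (0.85 log units; beyond the scatter). The earlier compounds shown here, none of them a single step from another, could not show this; here the loss of one carbon, with no ring, hydrogen-bond donor or hydrogen-bond acceptor entering or leaving, is enough to carry the number beyond the scatter. Nothing measured here bears on why this step is as large as it is.

From the compounds shown here alone, a single step makes no trend, so it remains open whether a propyl chain would lower the number further, or whether a hexyl chain would raise it again and so extend the direction seen here. Going by these compounds, it is also open whether a hydroxyl group or an amine at the end of the chain would be tolerated in place of the bare carbon chain, and whether trimming would act in the same way on the branched chain of compound 1.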